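Swapping ethyl for fluoro on a shared core

The compounds below may be only part of what the source reports. "The series", "measured", "known", "first", "only" and "open" are said of these compounds alone.

Measured in a functional assay on HL-60 cells (Homo sapiens) for cytotoxicity, read by WST assay, with a stated time of 48 h (on this read-out higher numbers stand for an effect only at larger amounts of compound and lower numbers for an effect already at smaller amounts), so far:
compound 1 `Cc1ccc(C[C@H]2COC[C@@H]2Cc2ccc(Cl)c(Cl)c2)cc1` gives 21000 nM
compound 2 `CCc1ccc(C[C@H]2COC[C@@H]2Cc2ccc(Cl)c(Cl)c2)cc1` gives 26000 nM

Among the measured compounds shown here, compound 2 holds the higher of only two numbers, but its one neighbour, compound 1, lies within the scatter of it, so the two cannot be told apart. Compound 3 `Fc1ccc(C[C@H]2COC[C@@H]2Cc2ccc(Cl)c(Cl)c2)cc1` differs from compound 2 on an aromatic carbon, para to a large group, where fluoro stands in place of ethyl: fluoro in place of ethyl on an aromatic carbon. For the measured compounds named here, one measured step bears on this, a 1.2-fold higher number from compound 1 to compound 2 (0.09 log units; within the scatter), where methyl gives way to ethyl at that same place. Going by the values given here, that step is small, yet no compound with fluoro has been measured, so it offers only indirect guidance. In this assay no change beyond the scatter is therefore expected. The expected step is a 1.1-fold higher number from compound 2 to compound 3 (0.03 log units; within the scatter) in this estimate. For compound 3 the estimated value is 28000 nM (range 13000 nM to 60000 nM).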

Compound 3, half-maximal effective concentration: 43000 nM
Beside the measured number, compound 3's estimate is 1.5-fold (0.19 log units) below it; measured number inside the range.
By their numbers in this assay, from the lowest: compounds 1, 2 and 3 (each within the scatter of the next, the first and the last beyond it).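

In this assay, fluoro in place of ethyl on this aromatic carbon gives a 1.7-fold higher number from compound 2 to compound 3 (0.22 log units; within the scatter) and so cannot be told apart from the ethyl compound. Fluoro in place of methyl at the same place gives a 2.0-fold higher number from compound 1 to compound 3 (0.31 log units; beyond the scatter) and is the first step at this position to pass the scatter, if only modestly, so the group on this carbon is shown to have some bearing on the number. No measurement is at hand that would explain this step.

The compounds shown leave open how an amine, a carboxylic acid or a longer chain on this aromatic carbon would read in this assay and whether any of them would bring an effect at smaller amounts of compound. They also leave open whether the modest step seen with fluoro would hold on repeated measurement.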